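A few compounds are considered here, and "the series" means these few. Any claim that something is new, unique, unknown or untested is made for them only; others in the source may bear on it.

In a functional assay on MCF7 cells (Homo sapiens) for cytotoxicity, read by XTT assay, with a stated time of 24 h (on this read-out lower numbers stand for stronger inhibition and higher numbers for weaker inhibition), compound 1 (`CC(=O)Oc1cc(C)c(Cl)c2c1C(=O)C=CC2=O`) gives 37900 nM and compound 2 (`CCOc1cc(C)cc2c1C(=O)C=CC2=O`) gives 23700 nM. Among the measured compounds shown here, these two numbers lie within the usual scatter of each other, so compound 2 cannot be ranked apart from the only other compound measured. For the measured compounds named here, the two compounds differ in more than one place, so they offer no clean single-change step. Compound 3 (`CCOc1cc(C)c(Cl)c2c1C(=O)C=CC2=O`) is compound 2 with chloro in place of hydrogen on an aromatic carbon, ortho to a methyl group and para to an ethoxy group: chloro in place of hydrogen on an aromatic carbon. Compound 1 also carries chloro and gives 37900 nM, so no step beyond the scatter is expected in this assay. The estimated step is a 1.2-fold lower number from compound 2 to compound 3 (0.07 log units; within the scatter). For compound 3 the estimated value is 20000 nM, with an expected range from 7000 nM to 50000 nM.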

Compound 3, half-maximal inhibitory concentration: 40000 nM
Beside the measured number, compound 3's estimate is 2.0-fold (0.30 log units) below it, within the range that was stated.
By their numbers in this assay, from the lowest: compounds 2, 1 and 3 (each within the scatter of the next).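

In this assay, among the compounds shown here, chloro in place of hydrogen on an aromatic carbon, ortho to a methyl group and para to an ethoxy group, gives a 1.7-fold higher number from compound 2 to compound 3 (0.23 log units; within the scatter) as the one clean reading of this position, so this change cannot be told apart from no change at all. The oxygen on the aromatic ring can now be read as well: ethyl in place of acetyl, with chloro present in both compounds, gives a 1.1-fold higher number from compound 1 to compound 3 (0.02 log units; within the scatter) and again stays too small to separate the pair. No measurement shown here explains either result. From the compounds shown here alone, whether an amine or a longer chain in place of chloro would move the number beyond the scatter remains open. So does whether a carboxylic acid on that oxygen would do so.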